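The compounds below may be only part of what the source reports. "The series", "measured", "known", "first", "only" and "open" are said of these compounds alone.

Compound 2 `COc1ccccc1-c1cc(C)c(Nc2ccnc(Nc3ccc(C#N)cc3)n2)c(C)c1` is one of three closely related compounds that have been tested in an ADME assay on MT4 cells (Homo sapiens) for cytotoxicity, read by MTT assay, with a stated time of 4 days (on this read-out higher numbers stand for lower toxicity in this test and lower numbers for higher toxicity in this test), where compound 2 gives 940 nM. Among the three numbers it stands second highest. Compound 3 `Cc1cc(-c2cccc(C#N)c2)cc(C)c1Nc1ccnc(Nc2ccc(C#N)cc2)n1` gives 920 nM, and the step of a 1.0-fold lower number from compound 2 to compound 3 (0.01 log units; within the scatter) is within the scatter, so the two compounds cannot be told apart on this read-out. Compound 1 `Cc1ccc(-c2cc(C)c(Nc3ccnc(Nc4ccc(C#N)cc4)n3)c(C)c2)cc1` gives 5570 nM, the highest of the three, and the step of a 5.9-fold lower number from compound 1 to compound 2 (0.77 log units; beyond the scatter) is beyond the scatter; the parallel step a 6.1-fold lower number from compound 1 to compound 3 (0.78 log units; beyond the scatter) is of similar size.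

The next compound is compound 4 `Cc1cc(-c2ccccc2Cl)cc(C)c1Nc1ccnc(Nc2ccc(C#N)cc2)n1`. Relative to compound 2 the difference is chloro in place of methoxy on an aromatic carbon.

Going by the values given here, no measured step covers a chloro for methoxy swap directly. The two steps that do exist, from compound 1 to compound 2 and from compound 1 to compound 3, show that changing the substituent on this ring can move the number modestly, while the step from compound 2 to compound 3 shows that two different substituents there can also give the same number. On that basis only a small step is expected, and the estimated step of a 1.1-fold higher number from compound 2 to compound 4 (0.03 log units; within the scatter) is taken to lie within the scatter. Compound 4 is therefore estimated to give 1000 nM, with a range from 400 nM to 2500 nM.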

Compound 4, half-maximal cytotoxic concentration: 3990 nM
Compound 4: the middle estimate sits 4.0-fold (0.60 log units) below what was measured; measured number above the stated range.
By their numbers in this assay, from the lowest: compounds 3 and 2 (each within the scatter of the next); then compounds 4 and 1 (each within the scatter of the next).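

This result shows that the group at this place matters even when the place itself stays the same: 2-chlorophenyl and 2-methoxyphenyl both carry their group ortho to a large group, yet chloro in place of methoxy gives a 4.2-fold higher number from compound 2 to compound 4 (0.63 log units; beyond the scatter), which in this assay means lower toxicity in this test. So the earlier match between compound 2 and compound 3 does not mean that changes on this ring tend to leave the number alone, since 2-chlorophenyl in place of 3-cyanophenyl gives a 4.3-fold higher number from compound 3 to compound 4 (0.64 log units; beyond the scatter), whereas 2-chlorophenyl in place of 4-methylphenyl gives a 1.4-fold lower number from compound 1 to compound 4 (0.14 log units; within the scatter), which leaves compound 1 and compound 4 indistinguishable and the four compounds in two pairs. Nothing available here explains why chloro and methoxy differ in this way.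

Open, on these data alone, is whether a fluoro or an amino group in this same place would fall with compound 2 and compound 3 or with compound 1 and compound 4. Also open, as far as these compounds go, is whether the number follows the chloro itself or its place on the ring, which only a chlorophenyl carrying its chloro elsewhere could show.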